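A few compounds are considered here, and "the series" means these few. Any claim that something is new, unique, unknown or untested is made for them only; others in the source may bear on it.

Working notes on the series in a functional assay with Oryctolagus cuniculus as the target; on this read-out lower numbers stand for stronger inhibition and higher numbers for weaker inhibition. Compound 3 (`COc1ccc(-c2nc(C(=O)N(C)C)sc2-c2ccc(OC)cc2)cc1`) is reported only as a limit, < 100 nM, so its standing is bounded on one side. Compound 1 (`COc1ccc(-c2nc(/N=C(\N)NC(C)C)sc2-c2ccc(OC)cc2)cc1`) is also a limit, > 100 nM. Compound 2 (`COc1ccc(-c2nc(/N=C(\N)[N+]3(C)CCCCC3)sc2-c2ccc(OC)cc2)cc1`) is a limit as well, > 1000 nM.

The next change leads to compound 4 (`CCOC(=O)/C=C/c1nc(-c2ccc(OC)cc2)c(-c2ccc(OC)cc2)s1`): 2-(ethoxycarbonyl)ethenyl in place of dimethylcarbamoyl on an aromatic carbon. Here 2-(ethoxycarbonyl)ethenyl enters in place of dimethylcarbamoyl on an aromatic carbon, and neither group has a net charge.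

Two measured steps change the group on this aromatic carbon. The step of an at least 10-fold lower number from compound 2 to compound 3 (1.00 log units; beyond the scatter) is the only readable size, while a number no higher from compound 1 to compound 3 (the limit leaves the size open) leaves its size open. Neither step involves 2-(ethoxycarbonyl)ethenyl, and both end at dimethylcarbamoyl, so they set no size for the new change. No clear step is therefore expected, only a wide uncertainty in either direction. The expected change is a step that the limit leaves unreadable from compound 3 to compound 4. The estimate for compound 4 is 50 nM. The estimated range for compound 4 runs from 8 nM to 300 nM.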

Compound 4, half-maximal inhibitory concentration: 20 nM
For compound 4 the middle estimate is 2.5-fold (0.40 log units) above the measured one; measured number inside the range.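

In this assay, among the compounds shown here, the 2-(ethoxycarbonyl)ethenyl group of compound 4 gives the first exact value at this aromatic carbon, where the earlier compounds gave only limits. The steps of an at least 5.0-fold lower number from compound 1 to compound 4 (0.69 log units; beyond the scatter) and an at least 50-fold lower number from compound 2 to compound 4 (1.69 log units; beyond the scatter) both favour this chain, which carries no nitrogen, over the two nitrogen-rich groups it replaces. The step to compound 4 from compound 3 cannot be read, since the value of compound 3 is a limit: the limit of < 100 nM in this assay, at which 1 of the 4 values shown sits.

As far as these compounds go, the order of compound 3 and compound 4 therefore stays open, as does whether the ethoxycarbonyl end or the double bond of the chain goes with the lower number. A carboxylic acid in place of the ethyl ester, or a saturated two-carbon link in place of the ethenyl, would bear on the second question.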